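From diethylamino to 4-methylpiperazin-1-yl on the chain

The compounds below may be only part of what the source reports. "The series", "measured", "known", "first", "only" and "open" are said of these compounds alone.

In a functional assay on HL-60 cells (Homo sapiens) for antiproliferative activity, read by MTT assay, with a stated time of 48 h (on this read-out higher numbers stand for weaker inhibition and lower numbers for stronger inhibition), compound 1 (`CCn1c(N)c(-c2nc3ccccc3[nH]2)c2nc(C#N)c(C#N)nc21`) is reported only as a limit, > 50000 nM and not a number. Among the compounds with values here, compound 2 (`CCN(CC)CCn1c(N)c(-c2nc3ccccc3[nH]2)c2nc(C#N)c(C#N)nc21`) stands at 1880 nM in this assay as the only number so far. Compound 3 (`CN1CCN(CCn2c(N)c(-c3nc4ccccc4[nH]3)c3nc(C#N)c(C#N)nc32)CC1`) carries the change 4-methylpiperazin-1-yl in place of diethylamino on a saturated chain carbon, two bonds along the chain from an aromatic nitrogen and keeps a group at that place. Within the data shown here, one measured step bears on this, and it is large (an at least 26-fold lower number from compound 1 to compound 2 (1.42 log units; beyond the scatter)), but it replaced hydrogen, so its size is not expected to repeat here. The estimated step is a 1.3-fold higher number from compound 2 to compound 3 (0.12 log units; within the scatter) and is expected to stay within the scatter. For compound 3 the expected value is 2500 nM within a range of 800 nM to 8000 nM in this assay as estimated.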

Compound 3, half-maximal inhibitory concentration: 4300 nM
Beside the measured number, compound 3's estimate is 1.7-fold (0.24 log units) below it; the range from low to high includes it.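

In this assay, the group at the end of the chain matters and not only its presence: 4-methylpiperazin-1-yl in place of diethylamino gives a 2.3-fold higher number from compound 2 to compound 3 (0.36 log units; beyond the scatter). The gain over hydrogen at this place is not confined to diethylamino, as 4-methylpiperazin-1-yl in place of hydrogen gives an at least 11-fold lower number from compound 1 to compound 3 (1.06 log units; beyond the scatter). The size of that gain stays bounded only, since compound 1 is reported as a limit and not a number: the limit of > 50000 nM in this assay, at which 1 of the 3 values shown sits.

Still open, as far as these compounds go, is whether morpholin-4-yl or dimethylamino on the same chain would lower the number. A longer chain carrying diethylamino is equally unresolved.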